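The source may report more compounds than this note shows. Statements on the series, on what has been measured and on what is new or still open speak of the compounds shown alone.

Measured in an ADME assay on HEK293 cells (Homo sapiens) for cytotoxicity, read by resazurin assay, with a stated time of 48 h; on this read-out lower numbers stand for higher toxicity in this test and higher numbers for lower toxicity in this test:
- Compound 1 `Cc1ccc(S(=O)(=O)Nc2ccc(-c3nc4ccccc4o3)cc2)cc1`: 88000 nM
- Compound 2 `Cc1cccc(S(=O)(=O)Nc2ccc(-c3nc4ccccc4o3)cc2)c1`: > 100000 nM

The entry for compound 2, > 100000 nM, is a limit of the assay and not a number. Compound 3 `O=S(=O)(Nc1ccc(-c2nc3ccccc3o2)cc1)c1ccc(Cl)cc1` differs from compound 2 by a single change, 4-chlorophenyl in place of 3-methylphenyl on a sulfonyl sulfur. Going by the values given here, only one measured step bears on this change, an at least 1.1-fold higher number from compound 1 to compound 2 (0.05 log units; that floor lies within the scatter), which swaps the aryl group at the same sulfonyl sulfur. On the strength of that step, no change beyond the scatter is expected in this assay, and the expected step is an at least 1.2-fold lower number from compound 2 to compound 3 (0.09 log units; that floor lies within the scatter). For compound 3 the estimated value is 80000 nM, with an expected range of 35000 nM to 150000 nM.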

Compound 3, half-maximal cytotoxic concentration: > 100000 nM
Compound 3 ended at the assay's limit (the forecaster's own chance of this, stated with the estimate: 35%); at least 1.2-fold (0.09 log units) between middle value and limit.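

In this assay compound 3 also stops at a limit of the assay, so the 4-chlorophenyl on the sulfonyl sulfur joins the 3-methylphenyl of compound 2 there. Chloro in place of methyl on an aromatic carbon gives an at least 1.1-fold higher number from compound 1 to compound 3 (0.05 log units; that floor lies within the scatter), so no shift beyond the scatter can be claimed. The step between compound 2 and compound 3 cannot be read, because both entries are limits: the limit of > 100000 nM in this assay, at which 2 of the 3 values shown sit.

From the compounds shown here alone, how far compound 2 and compound 3 lie past that limit stays open. So does whether an amine or a carboxylic acid on the aryl group at the sulfonyl sulfur would give a readable value.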